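The Pyrazole Gives Way to a Hydroxymethyl Pyridine

This account rests on a few compounds, and the source may have more. Where it says the series, first, only, none or still open, it means among the compounds named here.

Three measured compounds share one core and differ only in the ring attached to a single aromatic carbon. In a physicochemical assay for lipophilicity, using the shake flask method, in phosphate buffer, measured as octanol-water partition, with a stated time of 30 min, at pH 7.4 (a lower number here means a more polar compound, a higher number a more lipophilic compound), compound 1 `Cc1nccn1-c1cnc(NCc2c(F)ccc3c2CCO3)c2cn[nH]c(=O)c12` gives 2.1. Compound 2 `CNC(=O)c1ncc(-c2cnc(NCc3c(F)ccc4c3CCO4)c3cn[nH]c(=O)c23)n1C` gives 2.5 in this assay, and compound 3 `Cc1nn(C)cc1-c1cnc(NCc2c(F)ccc3c2CCO3)c2cn[nH]c(=O)c12` gives 2.8. Compound 3 stands highest of the three numbers; its nearest neighbour is compound 2, with a number 0.30 log units higher from compound 2 to compound 3 (within the scatter), and its furthest is compound 1, with a number 0.70 log units higher from compound 1 to compound 3 (beyond the scatter).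

Compound 4 `Cc1nc(CO)ccc1-c1cnc(NCc2c(F)ccc3c2CCO3)c2cn[nH]c(=O)c12` has not yet been measured. It differs from compound 3 in one place: 6-(hydroxymethyl)-2-methylpyridin-3-yl in place of 1,3-dimethyl-1H-pyrazol-4-yl on an aromatic carbon. The two measured steps that end at compound 3 both exchange one five-membered ring for another at this carbon, and both were modest at most. The change to compound 4 instead brings in a six-membered ring carrying a hydroxymethyl group with a hydrogen-bond donor, so the direction is only loosely anchored by the measured steps. Because compound 2 gives 2.5 with a methylcarbamoyl on its ring, a drop beyond the scatter is expected, a number 0.60 log units lower from compound 3 to compound 4 (beyond the scatter). Compound 4 is therefore estimated at 2.2, within a range from 1.7 to 2.7.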

Compound 4, distribution coefficient: 2.4
Compound 4: middle estimate off by 0.20 log units, on the low side, within the range that was stated.
By their numbers in this assay, from the lowest: compounds 1, 4, 2 and 3 (each within the scatter of the next, the first and the last beyond it).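

The new compound shows that this aromatic carbon can carry a six-membered ring as well as a five-membered one without leaving the range already seen. In this assay, among the compounds shown here, putting 6-(hydroxymethyl)-2-methylpyridin-3-yl in place of 1,3-dimethyl-1H-pyrazol-4-yl gives a number 0.40 log units lower from compound 3 to compound 4 (beyond the scatter), the only one of the new steps that clears the usual noise. Against the other two rings, the same group gives a number 0.10 log units lower from compound 2 to compound 4 (within the scatter) and a number 0.30 log units higher from compound 1 to compound 4 (within the scatter), so compound 4 cannot be told apart from either compound 2 or compound 1, even though compound 1 and compound 3 are clearly separated from each other.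

Nothing shown here offers an explanation for these steps. From the compounds shown here alone, since the change to compound 4 swaps the ring and brings in the hydroxymethyl group at once, the two contributions stay tangled, and it remains open what the same pyridine would give with a plain methyl, a methoxymethyl, an aminomethyl or a carboxylic acid in place of the hydroxymethyl.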